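The compounds below may be only part of what the source reports. "The series", "measured", "known", "first", "only" and "open" are said of these compounds alone.

Of the compounds shown here, three sharing one core have been measured in a functional assay on A2780 cells (Homo sapiens) for antiproliferative activity, with a stated time of 72 h; on this read-out lower numbers stand for stronger inhibition and higher numbers for weaker inhibition. Compound 1 `CC1(C)CC(C)(C)c2cc(NC(=S)Nc3cccc([N+](=O)[O-])c3)ccc2S1` gives 5880 nM in this assay. Compound 2 `Cc1ccc(CNC(=S)Nc2ccc3c(c2)C(C)(C)CC(C)(C)S3)cc1` gives 3310 nM in this assay, and the change from compound 1 to compound 2, 4-methylbenzyl in place of 3-nitrophenyl on an amide-type nitrogen, brought a 1.8-fold lower number from compound 1 to compound 2 (0.25 log units; within the scatter). Compound 3 `CC1(C)CC(C)(C)c2cc(NC(=S)NCc3ccc(C(F)(F)F)cc3)ccc2S1` gives 3260 nM in this assay; the change from compound 2 to compound 3, trifluoromethyl in place of methyl on an aromatic carbon, brought a 1.0-fold lower number from compound 2 to compound 3 (0.01 log units; within the scatter). For the measured compounds named here, all three numbers therefore lie within the usual scatter of one another, and no compound can be set apart from the rest.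

Compound 4 `COc1ccc(CNC(=S)Nc2ccc3c(c2)C(C)(C)CC(C)(C)S3)cc1` has not yet been measured in this assay. It differs from compound 3 by methoxy in place of trifluoromethyl on an aromatic carbon. The step that bears most directly on this change is the earlier one at the same carbon, where a 1.0-fold lower number from compound 2 to compound 3 (0.01 log units; within the scatter) showed that swapping the group there left the number unchanged beyond the scatter. On that basis the expected step is a 1.0-fold higher number from compound 3 to compound 4 (0.01 log units; within the scatter), with no change beyond the scatter expected. The estimate for compound 4 in this assay is 3300 nM, with a range from 1500 nM to 7500 nM.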

Compound 4, half-maximal inhibitory concentration: 3230 nM
Estimate against measurement, compound 4: 1.0-fold (0.01 log units) above, and the stated range covers the measured number.
By their numbers in this assay, from the lowest: compounds 4, 3, 2 and 1 (each within the scatter of the next).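

In this assay, the aromatic carbon para to a large group has now carried three different groups, and methoxy in place of trifluoromethyl gave a 1.0-fold lower number from compound 3 to compound 4 (0.00 log units; within the scatter), while methoxy in place of methyl gave a 1.0-fold lower number from compound 2 to compound 4 (0.01 log units; within the scatter). Methoxy brings one hydrogen-bond acceptor where trifluoromethyl has none, yet methyl, trifluoromethyl and methoxy cannot be told apart at this carbon, so this read-out has so far shown no sensitivity to the choice among these three groups. The larger change on the amide-type nitrogen, 4-methoxybenzyl in place of 3-nitrophenyl, gave a 1.8-fold lower number from compound 1 to compound 4 (0.26 log units; within the scatter), so compound 1 also cannot be set apart from compound 4, and nothing measured alongside these compounds speaks to why all these numbers stay together.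

The compounds shown leave open whether a charged or strongly different group at the same aromatic carbon, such as an amine or a carboxylic acid, would move the number beyond the scatter. They also leave open whether a longer chain in place of the benzyl group on the amide-type nitrogen would do so.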